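Demethylation on two related cores of retinoid benzoic acids

The source may report more compounds than this note shows. Statements on the series, on what has been measured and on what is new or still open speak of the compounds shown alone.

Measured so far:
compound 1, `CC1(C)CCC(C)(C)c2cc(C(=O)c3ccc4cc(C(=O)O)ccc4c3)c(O)cc21`, 44%
compound 2, `COc1cc2c(cc1C(=O)c1ccc3cc(C(=O)O)ccc3c1)C(C)(C)CCC2(C)C`, 23%
compound 3, `COc1c(C(=O)c2ccc3c(c2)C(C)(C)CCC3(C)C)ccc2cc(C(=O)O)ccc12`, 0%

Of the compounds shown here, three have been measured in an assay on isolated protein with retinoic acid receptor alpha (Homo sapiens) as the target; a lower number here means a smaller maximal response, a higher number a larger maximal response. Compound 1 `CC1(C)CCC(C)(C)c2cc(C(=O)c3ccc4cc(C(=O)O)ccc4c3)c(O)cc21` gives 44%, compound 2 `COc1cc2c(cc1C(=O)c1ccc3cc(C(=O)O)ccc3c1)C(C)(C)CCC2(C)C` gives 23%, and compound 3 `COc1c(C(=O)c2ccc3c(c2)C(C)(C)CCC3(C)C)ccc2cc(C(=O)O)ccc12` gives 0%, the lowest of the three numbers, beyond the scatter from each of the others.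

Compounds 2 and 1 differ in one place: hydrogen in place of methyl on an oxygen on an aromatic ring. This change gave a number 21 percentage points higher from compound 2 to compound 1 (beyond the scatter) in this assay, a modest but real step upward.

Compound 3 shares its atoms with compound 2 but joins them differently; the difference between the two cores is not broken down here. Compound 4 `CC1(C)CCC(C)(C)c2cc(C(=O)c3ccc4cc(C(=O)O)ccc4c3O)ccc21` has not yet been measured. It stands to compound 3 as compound 1 stands to compound 2: hydrogen in place of methyl on an oxygen on an aromatic ring, and the place is described in the same words in both cases, so it is the same change carried onto the other core.

For the measured compounds named here, only one measured instance of this change exists, so the expectation rests on it alone. If the step on the core of compound 3 resembles a number 21 percentage points higher from compound 2 to compound 1 (beyond the scatter), compound 4 is expected to rise from the baseline that compound 3 shows at 0% by roughly a number 15 percentage points higher from compound 3 to compound 4 (beyond the scatter). The estimate for compound 4 in this assay is therefore 15%, with a plausible range from 0% to 35%.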

Compound 4, largest response reached (reported as maximum), in percent of the reference or control that the assay uses: 0%
Compound 4: the middle estimate sits 15 percentage points above what was measured, and the stated range covers the measured number.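

Changing methoxy to hydroxy on the core of compound 3 gave no change at the digits printed from compound 3 to compound 4 (within the scatter) in this assay, so the rise seen on the first core did not reappear on the second. Set side by side, the two results for this change differ: the same change on two cores in this assay, a number 21 percentage points higher (beyond the scatter) from compound 2 to compound 1 and no change at the digits printed (within the scatter) from compound 3 to compound 4, 21 percentage points apart, beyond the scatter of two such steps

This shows that, in this series, the gain from the change on one core cannot be assumed to carry over to the other. It does not show why the two cores part ways, and with a single pair on each core it gives no rule for any further core; moreover, compound 3 already gives 0%, so only a rise could have been seen in this pair, and none was.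

The compounds shown leave open whether any other group on that oxygen, such as an ethyl group or a longer chain, would lift the response on the core of compound 4 from where it stands. They also leave open whether an amine in place of the hydroxy would behave differently on the two cores, or would follow the same split seen here.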